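The source may hold more compounds than are shown below. What is called first, only, known or untested is meant among the compounds shown, and "the series" means these compounds.

Measured compounds in a functional assay on A549 cells (Homo sapiens) for antiproliferative activity, read by CCK-8 assay, with a stated time of 72 h; on this read-out lower numbers stand for stronger inhibition and higher numbers for weaker inhibition:
compound 1 `O=C(Nc1cccc(-c2oc3cc(-c4ccc(F)cc4)ccc3c(=O)c2O)c1)c1ccc(Br)cc1`, 13500 nM
compound 2 `Cc1cc(C(=O)Nc2cccc(-c3oc4cc(-c5ccc(F)cc5)ccc4c(=O)c3O)c2)ccc1F`, 11500 nM
compound 3 `COc1cc(OC)cc(C(=O)Nc2cccc(-c3oc4cc(-c5ccc(F)cc5)ccc4c(=O)c3O)c2)c1`, 2390 nM

Compound 3 gives the lowest number of the three, and its gaps to the other two both lie beyond the scatter, as the steps of a 4.8-fold lower number from compound 2 to compound 3 (0.68 log units; beyond the scatter) and a 5.6-fold lower number from compound 1 to compound 3 (0.75 log units; beyond the scatter) show. Compound 1 and compound 2 sit within the scatter of each other: a 1.2-fold lower number from compound 1 to compound 2 (0.07 log units; within the scatter).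

Compound 4 `N#Cc1ccc(C(=O)Nc2cccc(-c3oc4cc(-c5ccc(F)cc5)ccc4c(=O)c3O)c2)cc1` has not been measured. It differs from compound 3 in one place: 4-cyanophenyl in place of 3,5-dimethoxyphenyl on a carbonyl carbon. The measured steps that bear on this change are the two that lead onto the 3,5-dimethoxyphenyl group, a 5.6-fold lower number from compound 1 to compound 3 (0.75 log units; beyond the scatter) and a 4.8-fold lower number from compound 2 to compound 3 (0.68 log units; beyond the scatter), both modest and both beyond the scatter. Compound 4, like compound 1 and compound 2, carries no methoxy group on the phenyl attached to the carbonyl carbon, so the step from compound 3 to compound 4 is expected to run the other way, back towards the numbers of compound 1 and compound 2, roughly a 3.8-fold higher number from compound 3 to compound 4 (0.58 log units; beyond the scatter). Compound 4 is therefore expected to give 9000 nM in this assay, with a range from 3000 nM to 25000 nM. Within the data shown here, no measured step involves a nitrile on this phenyl, so the range is kept wide.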

Compound 4, half-maximal inhibitory concentration: 2360 nM
For compound 4 the middle estimate is 3.8-fold (0.58 log units) above the measured one; measured number outside the range, below it.
By their numbers in this assay, from the lowest: compounds 4 and 3 (each within the scatter of the next); then compounds 2 and 1 (each within the scatter of the next).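

In this assay the step of a 1.0-fold lower number from compound 3 to compound 4 (0.01 log units; within the scatter) shows that, on this carbonyl carbon, the 4-cyanophenyl group cannot be told apart from the 3,5-dimethoxyphenyl group, so methoxy groups are not needed for the lowest numbers in the series. The steps of a 4.9-fold lower number from compound 2 to compound 4 (0.69 log units; beyond the scatter) and a 5.7-fold lower number from compound 1 to compound 4 (0.76 log units; beyond the scatter) are both modest and beyond the scatter, and the second is the cleanest comparison, since only cyano in place of bromo on an aromatic carbon separates the pair; among these four compounds, the two that carry a halogen on this phenyl, compound 1 and compound 2, give the higher numbers, and none of the four goes against this. No measured evidence at hand accounts for this result.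

Still open, on these data alone, is whether a single methoxy group, an amine or a carboxylic acid on this phenyl would group with compound 3 and compound 4 or with compound 1 and compound 2. Also open, as far as these compounds go, is whether a saturated ring such as cyclohexyl in place of the phenyl would hold the numbers of compound 3 and compound 4 in this assay.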